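This account rests on a few compounds, and the source may have more. Where it says the series, first, only, none or still open, it means among the compounds named here.

In a functional assay on cells (Homo sapiens) for cytotoxicity, read by MTT assay, with a stated time of 24 h (on this read-out higher numbers stand for weaker inhibition and lower numbers for stronger inhibition), the measured compounds give the following numbers:

compound 1 `CCCCCCCCCCCCCCNC(=O)[C@H](CO)NCc1ccccc1OC` gives 100000 nM
compound 2 `CCCCCCCCCCCCCCNC(=O)[C@H](CO)NCc1ccccc1[N+](=O)[O-]` gives 29400 nM
compound 3 `CCCCCCCCCCCCCCNC(=O)[C@H](CO)/N=C/c1cccc(O)c1` gives 32600 nM

Compound 3 holds the second highest of the three numbers. Compound 2 and compound 3 lie within the scatter of each other, so nothing separates them. Compound 1 sits apart: a 3.1-fold lower number from compound 1 to compound 3 (0.49 log units; beyond the scatter).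

Compound 4 `CCCCCCCCCCCCCCNC(=O)[C@H](CO)/N=C/c1cccc(C)c1` differs from compound 3 in one place, (methyl in place of hydroxy on an aromatic carbon); the same difference read one bond further out is 3-hydroxyphenyl to 3-methylphenyl.

Among the measured compounds shown here, no measured step swaps hydroxy for methyl. The two steps at hand both alter the aromatic part of the shared core and both are modest: a 3.4-fold lower number from compound 1 to compound 2 (0.53 log units; beyond the scatter) and a 3.1-fold lower number from compound 1 to compound 3 (0.49 log units; beyond the scatter). They show that changes at this part of the core have so far moved the numbers only modestly, and give no direction for the present swap. The step is therefore expected to be small, a 1.1-fold higher number from compound 3 to compound 4 (0.03 log units; within the scatter), with no change beyond the scatter the most likely outcome. Compound 4 is estimated at 35000 nM, with a range from 12000 nM to 100000 nM.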

Compound 4, half-maximal inhibitory concentration: 82900 nM
Beside the measured number, compound 4's estimate is 2.4-fold (0.37 log units) below it; measured number inside the range.
By their numbers in this assay, from the lowest: compounds 2 and 3 (each within the scatter of the next); then compounds 4 and 1 (each within the scatter of the next).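

In this assay, among the compounds shown here, the swap of hydroxy for methyl, on an aromatic carbon meta to a large group, gives the first reading of this position with the rest of the shared core unchanged: a 2.5-fold higher number from compound 3 to compound 4 (0.41 log units; beyond the scatter) is a modest step beyond the scatter, so this position responds to the group it carries. The other new step, a 1.2-fold lower number from compound 1 to compound 4 (0.08 log units; within the scatter), lies within the scatter, so compound 4 does not stand apart from that compound as compound 3 does. No available measurement bears on the cause of the step from hydroxy to methyl.

From the compounds shown here alone, whether an amine or a carboxylic acid on this aromatic carbon would read closer to compound 3 or to compound 4 remains open. Also open, going by these compounds, is whether a shorter chain in place of the long chain on the amide would alter the size of this step.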